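The source may hold more compounds than are shown below. What is called first, only, known or untested is meant among the compounds shown, and "the series" means these compounds.

Compound 1 `CNC(=O)c1c(O)c2cccnc2n(-c2ccccc2)c1=O` carries the shared core with a methyl group on its amide-type nitrogen. In a functional assay on the whole organism for inhibition, with Rattus norvegicus as the target, read by paw edema, at a dose of 100 mg/kg by the oral route (a lower number here means less inhibition, a higher number more inhibition at the dose given (going by the name of the read-out)), compound 1 gives 9.6%. Compound 2 `CN(C)CCNC(=O)c1c(O)c2cccnc2n(-c2ccccc2)c1=O` gives 22.6% in this assay, and compound 3 `O=C(Nc1cccc([N+](=O)[O-])c1)c1c(O)c2cccnc2n(-c2ccccc2)c1=O` gives 5.7%. Compound 3 thus has the lowest number of the three, but its gap to compound 1 lies within the scatter; only compound 2 stands clearly apart, as the step of a number 16.9 percentage points lower from compound 2 to compound 3 (beyond the scatter) shows.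

Compound 4 `O=C(NCc1ccncc1)c1c(O)c2cccnc2n(-c2ccccc2)c1=O` differs from compound 3 in one place: (pyridin-4-yl)methyl in place of 3-nitrophenyl on an amide-type nitrogen. For the measured compounds named here, two measured steps bear on this change. The step of a number 13 percentage points higher from compound 1 to compound 2 (beyond the scatter) shows that a substituent reaching the amide-type nitrogen through a saturated chain carbon raised the number beyond the scatter, whereas the step of a number 3.9 percentage points lower from compound 1 to compound 3 (within the scatter) shows that exchanging methyl for 3-nitrophenyl stayed within the scatter. Since (pyridin-4-yl)methyl, like 2-(dimethylamino)ethyl, joins the amide-type nitrogen through a saturated chain carbon, a modest rise is expected, estimated as a number 9.3 percentage points higher from compound 3 to compound 4 (within the scatter). Compound 4 is therefore expected to give about 15% in this assay, with a likely range from 3% to 30%, the outcome to be settled by measurement.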

Compound 4, a percentage reported as inhibition, in the whole organism at one dose (the size of the read-out at that dose, not a potency): 10%
Estimate against measurement, compound 4: 5 percentage points above; the measured number falls inside the stated range.
By their numbers in this assay, from the lowest: compounds 3, 1 and 4 (each within the scatter of the next); then compound 2.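

In this assay, reaching the amide-type nitrogen through a saturated chain carbon does not by itself set a compound apart: a number 0.4 percentage points higher from compound 1 to compound 4 (within the scatter), and a number 4.3 percentage points higher from compound 3 to compound 4 (within the scatter). At this position, then, (pyridin-4-yl)methyl cannot be told apart from either methyl or 3-nitrophenyl, so the earlier reading of the chain carbon as the feature linked to the higher number does not hold for this pair. What separates the compounds is what that chain carbon carries, as a number 12.6 percentage points lower from compound 2 to compound 4 (beyond the scatter), which leaves compound 2 alone in standing clear of the other three. No measurement among the data accounts for this difference between the two groups.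

The compounds shown leave open whether the higher number of compound 2 goes with the dimethylamino group itself or with the chain that carries it, which a 2-(diethylamino)ethyl, a 2-(morpholin-4-yl)ethyl or a 3-(dimethylamino)propyl group on the same nitrogen could separate. They also leave open how a carboxylic acid at the end of that chain would read, and whether any of these numbers would hold at another dose.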